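Chloro to fluoro exchange and cytotoxicity on Vero cells

A few compounds are considered here, and "the series" means these few. Any claim that something is new, unique, unknown or untested is made for them only; others in the source may bear on it.

Compound 1 `Cc1c(C(=O)NCc2ccccc2)[n+]([O-])c2cc(Cl)ccc2[n+]1[O-]` and compound 2 `Cc1c(C(=O)NCc2ccccc2)[n+]([O-])c2cc(F)ccc2[n+]1[O-]` were tested in an ADME assay on Vero cells (Chlorocebus sabaeus) for cytotoxicity, read by MTT assay, with a stated time of 72 h; a lower number here means a stronger inhibitor, a higher number a weaker inhibitor. Compound 1 gives only a limit of the assay, > 100 ug/mL. Compound 2 likewise gives only a limit, > 100 ug/mL. The change between them is fluoro in place of chloro on an aromatic carbon, and the step that the two limits leave unreadable from compound 1 to compound 2, since both values sit at the limit of > 100 ug/mL in this assay, at which 2 of the 3 values shown sit. Compound 3 `COc1ccc(CNC(=O)c2c(C)[n+]([O-])c3ccc(Cl)cc3[n+]2[O-])cc1` differs from compound 1 by methoxy in place of hydrogen on an aromatic carbon; in this assay compound 3 is "not determined" (no result reported). Compound 4 `COc1ccc(CNC(=O)c2c(C)[n+]([O-])c3ccc(F)cc3[n+]2[O-])cc1` carries the same kind of change from compound 3, (fluoro in place of chloro on an aromatic carbon), with the same surroundings of the place as between compound 1 and compound 2. No step size is readable from the measured pair, so the expectation for compound 4 rests only on both measured analogues sitting at the limit; compound 4 is estimated at 100 ug/mL in this assay, most likely again reported as a limit.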

Compound 4, half-maximal inhibitory concentration: > 30 ug/mL
Compound 4: only a limit was reported (the forecaster's own chance of this, stated with the estimate: 80%); the middle value lies beyond the limit too.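

In this assay compound 2 gives only a limit, > 100 ug/mL. Within the data shown here, compound 4 also gives only a limit, > 30 ug/mL, so no step between compound 2 and compound 4 can be read. Open, as far as these compounds go, is where the actual values of both compounds lie in this assay, and whether methoxy in place of hydrogen changes them at all.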